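Cyclopropyl(propyl)amino in Place of (1-Methylbutyl)amino

This account rests on a few compounds, and the source may have more. Where it says the series, first, only, none or still open, it means among the compounds named here.

Measured compounds:
Compound 1 `C=CCN(CC=C)c1nc(C)nc2c(-c3c(C)cc(OC)cc3OC)c(C)nn12` gives 1 nM in an assay on cell membranes for displacement of a labelled ligand from corticotropin-releasing factor receptor 1 (Rattus norvegicus); on this read-out higher numbers stand for weaker inhibition and lower numbers for stronger inhibition.
Compound 2 `CCCN(CCC)c1nc(C)nc2c(-c3c(C)cc(OC)cc3OC)c(C)nn12` gives 3.72 nM in this assay.
Compound 3 `CCCC(C)Nc1nc(C)nc2c(-c3c(C)cc(OC)cc3OC)c(C)nn12` gives 2.14 nM in this assay.

Compound 3 stands second highest of the three numbers. Its nearest neighbour is compound 2, with a 1.7-fold lower number from compound 2 to compound 3 (0.24 log units; within the scatter); its furthest is compound 1, with a 2.1-fold higher number from compound 1 to compound 3 (0.33 log units; beyond the scatter).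

Compound 4 `CCCN(c1nc(C)nc2c(-c3c(C)cc(OC)cc3OC)c(C)nn12)C1CC1` has not yet been measured. The change from compound 3 is cyclopropyl(propyl)amino in place of (1-methylbutyl)amino on an aromatic carbon.

Within the data shown here, two measured steps bear on this. The step of a 3.7-fold higher number from compound 1 to compound 2 (0.57 log units; beyond the scatter) shows that swapping the groups on a tertiary amine at this position can move the number modestly. The step of a 1.7-fold lower number from compound 2 to compound 3 (0.24 log units; within the scatter) shows that going from a tertiary to a branched secondary amine stays within the scatter. Compound 4 returns to a tertiary amine bearing a propyl chain, as in compound 2, plus a cyclopropyl ring. No step beyond the scatter is therefore expected: compound 4 is estimated at 3 nM (range 1.2 nM to 8 nM), an expected change of a 1.4-fold higher number from compound 3 to compound 4 (0.15 log units; within the scatter).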

Compound 4, half-maximal inhibitory concentration: 1.48 nM
Compound 4: middle estimate off by 2.0-fold (0.31 log units), on the high side, and the stated range covers the measured number.
By their numbers in this assay, from the lowest: compounds 1, 4, 3 and 2 (each within the scatter of the next, the first and the last beyond it).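

In this assay, the swap of cyclopropyl for propyl on the nitrogen gives a 2.5-fold lower number from compound 2 to compound 4 (0.40 log units; beyond the scatter), which shows that a three-membered ring on this amine can shift the number beyond the scatter, whereas the earlier tertiary amines differed only in their open chains. The secondary amine's hydrogen-bond donor is also not needed to reach this range: with none on the tertiary amine, the result is a 1.4-fold lower number from compound 3 to compound 4 (0.16 log units; within the scatter), and the comparison with diallylamino gives a 1.5-fold higher number from compound 1 to compound 4 (0.17 log units; within the scatter), both within the scatter. Nothing available explains why the ring shifts the number.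

The compounds shown leave open whether a larger ring on this nitrogen, such as cyclobutyl or cyclopentyl, would act as cyclopropyl does. They also leave open whether cyclopropyl would keep this effect alongside a chain other than propyl, such as methoxyethyl or allyl.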